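A few compounds are considered here, and "the series" means these few. Any claim that something is new, unique, unknown or untested is made for them only; others in the source may bear on it.

Compound 1 `Nc1ncnc2c1nc(NCCCCNC(=O)CI)n2[C@@H]1O[C@H](COP(=O)(O)OP(=O)(O)OP(=O)(O)O)[C@@H](O)[C@H]1O`, compound 2 `O=C(CI)NCCCCC(=O)NCCCCCCNc1ncnc2c1ncn2[C@@H]1O[C@H](COP(=O)(O)OP(=O)(O)OP(=O)(O)O)[C@@H](O)[C@H]1O` and compound 3 `O=C(CI)NCCCCCCC(=O)NCCCCCCNc1ncnc2c1ncn2[C@@H]1O[C@H](COP(=O)(O)OP(=O)(O)OP(=O)(O)O)[C@@H](O)[C@H]1O` all carry a triphosphate-bearing adenosine core joined to a chain that ends in an iodoacetamide. In an assay on isolated protein for inhibition of hexokinase-3 (Rattus norvegicus), with a stated time of 6 h, tested at 10 mM (on this read-out higher numbers stand for more inhibition at the one concentration tested (going by the name of the read-out) and lower numbers for less inhibition), compound 1 gives 0%, compound 2 gives 0%, and compound 3 gives 0%. The difference between the core of compound 1 and the core of compound 2 is not broken down here. Compound 3 differs from compound 2 by 2-(((iodomethyl)carbonyl)amino)ethyl in place of ((iodomethyl)carbonyl)amino on a saturated chain carbon, four bonds along the chain from a carbonyl carbon, and this step, no change at the digits printed from compound 2 to compound 3 (within the scatter), left the read-out unchanged.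

Compound 4 `Nc1ncnc2c1nc(NCCCCCCNC(=O)CI)n2[C@@H]1O[C@H](COP(=O)(O)OP(=O)(O)OP(=O)(O)O)[C@@H](O)[C@H]1O` has not been measured. It differs from compound 1 by 2-(((iodomethyl)carbonyl)amino)ethyl in place of ((iodomethyl)carbonyl)amino on a saturated chain carbon, four bonds along the chain from a nitrogen on an aromatic ring. Around the place the two changes are not identical: in compound 2 the chain carbon is four bonds along the chain from a carbonyl carbon, in compound 1 it is four bonds along the chain from a nitrogen on an aromatic ring, so the change is the same kind of change, not the same. Because the earlier step of no change at the digits printed from compound 2 to compound 3 (within the scatter) showed no movement, and because compound 1 already gives 0%, a step of about no change at the digits printed from compound 1 to compound 4 (within the scatter) is expected. Compound 4 is therefore estimated at 0% in this assay, within -8% to 10%.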

Compound 4, a percentage reported as inhibition, at one concentration (the size of the read-out at that concentration, not a potency): 0%
Beside the measured number, compound 4's estimate shows no gap at the digits printed; the measured number falls inside the stated range.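

In this assay, putting 2-(((iodomethyl)carbonyl)amino)ethyl in place of ((iodomethyl)carbonyl)amino gives no change at the digits printed from compound 1 to compound 4 (within the scatter), and the earlier step on the other core reads alike: the same change on two cores in this assay, no change at the digits printed (within the scatter) from compound 2 to compound 3 and no change at the digits printed (within the scatter) from compound 1 to compound 4, 0 percentage points apart, within the scatter of two such steps

So within this small set, the change carries from one core to the other without moving the read-out at the one concentration tested. This agreement is only between two steps that show no movement: compound 1 gives 0% and compound 4 gives 0%, so neither step starts from any measurable inhibition. It therefore does not show that the change would be equally silent on a core that does inhibit the enzyme.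

The compounds shown leave open whether a longer chain, or a chloroacetamide or an acrylamide in place of the iodoacetamide, would give any inhibition in this assay. They also leave open whether a diphosphate in place of the triphosphate would do so on either core.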